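An Indole Linked Through Nitrogen in Place of Chlorophenoxy

The source may report more compounds than this note shows. Statements on the series, on what has been measured and on what is new or still open speak of the compounds shown alone.

Of the compounds shown here, three built on one shared core have been measured in an assay on isolated protein for binding affinity to 5-hydroxytryptamine receptor 7 (Homo sapiens); on this read-out higher numbers stand for weaker inhibition and lower numbers for stronger inhibition. Compound 1 `O=C1c2ccccc2CCCC1CCN1CCC(Oc2ccccc2)CC1` gives 25.1 nM. Compound 2 `O=C1c2ccccc2CCCN1CCN1CCC(Oc2ccc(Cl)cc2)CC1` gives 11.8 nM, the second highest of the three numbers, close to compound 1 and far from compound 3. Compound 3 `O=C1c2ccccc2CCCN1CCN1CCC(c2c[nH]c3ccccc23)CC1` gives 0.407 nM, the lowest number of the set.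

Only one pair of these compounds differs in a single place: the step of a 29-fold lower number from compound 2 to compound 3 (1.46 log units; beyond the scatter), where 1H-indol-3-yl replaces 4-chlorophenoxy on a saturated ring carbon.

Compound 4 `O=C1c2ccccc2CCCN1CCN1CCC(n2ccc3ccccc32)CC1` has not yet been measured. It differs from compound 2 by 1H-indol-1-yl in place of 4-chlorophenoxy on a saturated ring carbon: 1H-indol-1-yl in place of 4-chlorophenoxy, on a saturated ring carbon of a six-membered non-aromatic ring with 1 nitrogen, three ring bonds from the ring nitrogen. The entering group is the same two-ring indole as in compound 3, but joined to the core through its nitrogen rather than through a ring carbon. Within the data shown here, the step from compound 2 to compound 3 is the only measured step that bears on this change, and it was large. Because the step of a 29-fold lower number from compound 2 to compound 3 (1.46 log units; beyond the scatter) was a strong lowering, a lowering is also expected for compound 4. Among the measured compounds shown here, no measured compound carries an indole joined through nitrogen, so the expected step from compound 2 to compound 4 is set more modestly at a 3.9-fold lower number from compound 2 to compound 4 (0.59 log units; beyond the scatter). The estimate for compound 4 in this assay is 3 nM, with a range from 0.8 nM to 12 nM.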

Compound 4, inhibition constant: 2.75 nM
For compound 4 the middle estimate is 1.1-fold (0.04 log units) above the measured one; low and high end bracket the measured number.
By their numbers in this assay, from the lowest: compound 3; then compound 4; then compound 2; then compound 1.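

At this saturated ring carbon, three ring bonds from the ring nitrogen, the lower number seen with an indole does not require attachment through a ring carbon: this assay records a 4.3-fold lower number from compound 2 to compound 4 (0.63 log units; beyond the scatter) for the indole joined through its nitrogen. The attachment point still counts, since swapping 1H-indol-3-yl for 1H-indol-1-yl, with the same two rings in both groups, gives a 6.8-fold higher number from compound 3 to compound 4 (0.83 log units; beyond the scatter) and so gives back part of the drop seen with compound 3. Nothing available here explains why the joining atom changes the number.

The compounds shown cannot separate the effect of where the indole is joined from the effect of the hydrogen on the nitrogen of the indole in compound 3, a question that an indole joined through the same ring carbon but carrying a methyl on its nitrogen would address. They also leave open how much of the two-ring indole is needed at this ring carbon and how the number responds to a substituent on it, such as a fluorine, a methoxy group or an amine on the six-membered ring.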